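Swapping Trifluoromethyl for Chloro on the Urea Aryl Ring

The compounds below may be only part of what the source reports. "The series", "measured", "known", "first", "only" and "open" are said of these compounds alone.

Measured in a functional assay on COLO 205 cells (Homo sapiens) for inhibition, read by sulforhodamine B assay, with a stated time of 48 h, tested at 0.1 uM; a lower number here means a stronger effect, a higher number a weaker effect of the compound at the concentration tested:
Compound 1, `O=C(Nc1cccc(-n2cc(-c3ccncc3)c(-c3cc(O)cc(Cl)c3)n2)c1)Nc1ccc(Cl)c(C(F)(F)F)c1`, gives 95%.
Compound 2, `O=C(Nc1cccc(-n2cc(-c3ccncc3)c(-c3cc(O)cc(Cl)c3)n2)c1)Nc1ccc(Cl)c(Cl)c1`, gives 103%.
Compound 3, `COc1cc(Cl)cc(-c2nn(-c3cccc(NC(=O)Nc4ccc(Cl)c(C(F)(F)F)c4)c3)cc2-c2ccncc2)c1`, gives 99%.

Among these three numbers, compound 3 has the second highest; its nearest neighbour is compound 1, the step being a number 4 percentage points higher from compound 1 to compound 3 (within the scatter), and its furthest is compound 2, a gap that also lies within the usual scatter. All three compounds thus leave the cells essentially untouched at this concentration.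

Compound 4, `COc1cc(Cl)cc(-c2nn(-c3cccc(NC(=O)Nc4ccc(Cl)c(Cl)c4)c3)cc2-c2ccncc2)c1`, differs from compound 3 in one place: chloro in place of trifluoromethyl on an aromatic carbon. The same exchange has already been seen once, on the pair carrying a hydrogen rather than a methyl on the oxygen, where it gave a number 8 percentage points higher from compound 1 to compound 2 (within the scatter). Going by the values given here, that single precedent is the only direct guide, and it showed no movement beyond the scatter.

Compound 4 is therefore expected to show a number 4 percentage points higher from compound 3 to compound 4 (within the scatter), no step beyond the scatter in this assay. The estimated value for compound 4 is 103%, with a likely range from 92% to 114%.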

Compound 4, a percentage reported as activity, at one concentration (the size of the read-out at that concentration, not a potency): 103%
Beside the measured number, compound 4's estimate shows no gap at the digits printed; the range from low to high includes it.
By their numbers in this assay, from the lowest: compounds 1, 3, 2 and 4 (each within the scatter of the next).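

Exchanging trifluoromethyl for chloro has now been seen on a second core in this assay, and here it gives a number 4 percentage points higher from compound 3 to compound 4 (within the scatter), so the earlier reading no longer rests on a single pair: the same change on two cores in this assay, a number 8 percentage points higher (within the scatter) from compound 1 to compound 2 and a number 4 percentage points higher (within the scatter) from compound 3 to compound 4, 4 percentage points apart, within the scatter of two such steps. The four compounds also allow methyl in place of hydrogen on the oxygen to be read a second time, now with chloro on the urea aryl ring, and this gives no change at the digits printed from compound 2 to compound 4 (within the scatter): the same change on two cores in this assay, a number 4 percentage points higher (within the scatter) from compound 1 to compound 3 and no change at the digits printed (within the scatter) from compound 2 to compound 4, 4 percentage points apart, within the scatter of two such steps. Neither change moves the read-out beyond the scatter on either core, so the four compounds cannot be told apart at this single concentration.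

Still open, as far as these compounds go, is whether another group on this aromatic carbon, such as bromo, methyl or nitrile, would give a number outside the scatter. These values also cannot show how either change would behave at a concentration where the cells respond.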